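From methyl to tert-butoxy on the aromatic ring

A few compounds are considered here, and "the series" means these few. Any claim that something is new, unique, unknown or untested is made for them only; others in the source may bear on it.

compound 1 `COc1ccc(-c2nnc(SCCCN3CCN(c4nc5ccccc5o4)CC3)o2)cc1`: 66100 nM
compound 2 `Cc1ccc(-c2nnc(SCCCN3CCN(c4nc5ccccc5o4)CC3)o2)cc1`: 154000 nM
compound 3 `Cc1ccc(-c2nnc(SCCCN3CCN(c4nc5ccccc5s4)CC3)o2)cc1`: 96700 nM

In a functional assay on HepG2 cells (Homo sapiens) for inhibition, read by MTT assay, with a stated time of 72 h (a lower number here means a stronger inhibitor, a higher number a weaker inhibitor), compound 3 gives 96700 nM, a number within the scatter of both compound 1 and compound 2, although those two differ from each other beyond it.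

Compound 4 `CC(C)(C)Oc1ccc(-c2nnc(SCCCN3CCN(c4nc5ccccc5s4)CC3)o2)cc1` keeps the rest of compound 3 and changes one group: tert-butoxy in place of methyl on an aromatic carbon. In words, tert-butoxy sits in place of methyl on an aromatic carbon, para to a large group.

Among the measured compounds shown here, two measured steps bear on this. The closer one is a 2.3-fold higher number from compound 1 to compound 2 (0.37 log units; beyond the scatter), a modest step with methyl in place of methoxy. Read in reverse, it pairs the oxygen-bearing group with the lower number. The other is a 1.6-fold lower number from compound 2 to compound 3 (0.20 log units; within the scatter), with 1,3-benzothiazol-2-yl in place of 1,3-benzoxazol-2-yl, so the first step may carry over. For the measured compounds named here, no measured compound carries tert-butoxy, which leaves the size uncertain.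

A modest move to a lower number in this assay is therefore expected, estimated as a 1.6-fold lower number from compound 3 to compound 4 (0.21 log units; within the scatter). For compound 4 the estimated value is 60000 nM, with an expected range of 25000 nM to 140000 nM.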

Compound 4, half-maximal inhibitory concentration: 202000 nM
Estimate against measurement, compound 4: 3.4-fold (0.53 log units) below; measured number above the stated range.
By their numbers in this assay, from the lowest: compounds 1, 3, 2 and 4 (each within the scatter of the next, the first and the last beyond it).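

Carrying an oxygen on this aromatic carbon, para to a large group, does not by itself go with a lower number. In this assay, tert-butoxy in place of methyl gives a 2.1-fold higher number from compound 3 to compound 4 (0.32 log units; beyond the scatter), the opposite direction to methoxy, which went with the lower number in the pair linked by a 2.3-fold higher number from compound 1 to compound 2 (0.37 log units; beyond the scatter). The two changes sit on different cores, so the earlier pair shows only that methoxy and tert-butoxy need not act alike here, and nothing measured on these compounds explains the difference.

Among the compounds shown here, still open is how methoxy behaves when the amine nitrogen carries 1,3-benzothiazol-2-yl, the one comparison that would set it directly against compound 3 and compound 4. Also open, on these data alone, is where ethoxy or a hydroxy group on this same carbon would fall relative to methyl and tert-butoxy.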